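Chain-length trimming on the shared core: compound 1 to compound 3

The source may report more compounds than this note shows. Statements on the series, on what has been measured and on what is new or still open speak of the compounds shown alone.

Measured so far:
- compound 1, `C=CCCCn1c(Cc2cc(OC)c(OC)c(OC)c2)nc2c(N)nc(F)nc21`, gives 44700 nM in a functional assay on MCF7 cells (Homo sapiens) for antiproliferative activity; a lower number here means a stronger inhibitor, a higher number a weaker inhibitor
- compound 2, `COc1cc(Cc2nc3c(N)nc(F)nc3n2CCOC(C)C)c(Cl)c(OC)c1OC`, gives 5370 nM in this assay

Compound 1 stands at the highest number of the two, the weaker inhibitor; compound 2 sits at a lower number, and the gap between the two lies beyond the scatter. The two differ in more than one place, so nothing is read into that gap beyond what the values show.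

Compound 3, `CCCn1c(Cc2cc(OC)c(OC)c(OC)c2)nc2c(N)nc(F)nc21`, has not been measured. Relative to compound 1 the change is hydrogen in place of vinyl on a saturated chain carbon, three bonds along the chain from an aromatic nitrogen; the chain is shortened and nothing else on the shared core moves. For the measured compounds named here, no measured pair in the set isolates a chain-length change, so the step from compound 1 is expected to be small, with no direction beyond the scatter favored. The expected step is a 1.2-fold lower number from compound 1 to compound 3 (0.07 log units; within the scatter). For compound 3 the estimate is 38000 nM, within 12000 nM to 110000 nM.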

Compound 3, half-maximal inhibitory concentration: 25100 nM
The estimate for compound 3 lay 1.5-fold (0.18 log units) above the measured number, within the range that was stated.
By their numbers in this assay, from the lowest: compound 2; then compounds 3 and 1 (each within the scatter of the next).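

In this assay, for the compounds shown here, the chain change gives a 1.8-fold lower number from compound 1 to compound 3 (0.25 log units; within the scatter), the first comparison that isolates a single place, and pent-4-en-1-yl and propyl are not told apart on the shared core. Within this pair, then, the vinyl at this place, with its double bond outside aromatic rings, is not required for a number in the range of compound 1. No measurement at hand offers an explanation for this result.

From the compounds shown here alone, whether an amine, a carboxylic acid or a longer chain at this place would give a number beyond the scatter from compound 3 remains open. Compound 2 differs from both other compounds in more than one place, so its lower number cannot be assigned to any single change.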